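Aryl swap on the amide arm of the chromene series

The source may report more compounds than this note shows. Statements on the series, on what has been measured and on what is new or still open speak of the compounds shown alone.

Compound 1 `CCOC(=O)C1=Cc2ccccc2OC1(OCc1cn(CC(=O)Nc2ccccc2Br)nn1)C(F)(F)F` carries a triazole arm ending in an anilide. For the measured compounds named here, in a functional assay on DU-145 cells (Homo sapiens) for inhibition, read by MTT assay, with a stated time of 24 h (a higher number here means a weaker inhibitor, a lower number a stronger inhibitor), compound 1 gives only a limit of the assay, > 150000 nM, so its own position on the scale is not fixed; it shares that limit with no other member here, as the limit of > 150000 nM in this assay, at which 1 of the 3 values shown sits, records. The two isoxazole members are numbered. In this assay, going by the values given here, compound 2 `CCOC(=O)C1=Cc2ccccc2OC1(OCc1cc(-c2ccc(Br)cc2)no1)C(F)(F)F` gives 71700 nM, and compound 3 `CCOC(=O)C1=Cc2ccccc2OC1(OCc1cc(-c2ccc3ccccc3c2)no1)C(F)(F)F` gives 71800 nM; the only measured step, a 1.0-fold higher number from compound 2 to compound 3 (0.00 log units; within the scatter), shows that exchanging one aromatic group for another on that arm left the read-out unchanged within the scatter.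

Compound 4 `CCOC(=O)C1=Cc2ccccc2OC1(OCc1cn(CC(=O)Nc2ccc(I)cc2Cl)nn1)C(F)(F)F` is not yet measured. Against compound 1 it shows the difference (2-chloro-4-iodophenyl in place of 2-bromophenyl on an amide-type nitrogen). Among the compounds with values here, no measured step touches this arm directly; the isoxazole step is the nearest analogue and was flat. With compound 1 sitting at a limit, the expectation is a number of the same kind, and the step of a number no higher from compound 1 to compound 4 (the limit leaves the size open) is therefore expected to be small, with a real chance that the assay again reports only a limit. Compound 4 is estimated at 150000 nM, with a range from 60000 nM to 400000 nM.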

Compound 4, half-maximal inhibitory concentration: 24400 nM
Compound 4: middle estimate off by 6.1-fold (0.79 log units), on the high side; measured number below the stated range.
By their numbers in this assay, from the lowest: compound 4; then compounds 2 and 3 (each within the scatter of the next). At a limit, above all of these: compound 1.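

In this assay, for the compounds shown here, the change to 2-chloro-4-iodophenyl on the amide-type nitrogen gives an at least 6.1-fold lower number from compound 1 to compound 4 (0.78 log units; beyond the scatter), whereas the only earlier step, an aromatic exchange on the isoxazole arm, gave a 1.0-fold higher number from compound 2 to compound 3 (0.00 log units; within the scatter). The aryl group on this anilide arm is therefore a place where the read-out can move, and with compound 4 at 24400 nM the triazole arm now has a measured number. Compound 1 stands at a limit, so the full size of this step stays open: the limit of > 150000 nM in this assay, at which 1 of the 4 values shown sits.

The change exchanges 2-bromophenyl for a ring carrying both chlorine and iodine, so the compounds shown cannot assign the step to either halogen, or to the loss of bromine, and a single pair does not establish a trend for this arm. Also open, from the compounds shown here alone, is whether the number holds when a non-halogen group, such as a methoxy group, an amine or a carboxylic acid, stands on the phenyl ring in place of the iodine.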